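The source may hold more compounds than are shown below. What is called first, only, known or untested is meant among the compounds shown, and "the series" means these compounds.

Measured in a functional assay on HCC 2998 cells (Homo sapiens) for inhibition, read by colorimetric assay and sulforhodamine B assay, with a stated time of 48 h; on this read-out higher numbers stand for weaker inhibition of growth and lower numbers for stronger inhibition of growth:
- compound 1 `CCCCCCCCCCCC[C@@H](O)[C@H]1CC[C@H]([C@H](O)CCCCCCCCCCNC(=O)c2cccs2)O1`: 2000 nM
- compound 2 `CCCCCCCCCCCC[C@@H](O)[C@H]1CC[C@H]([C@H](O)CCCCCCCCCCNC(=O)c2ccco2)O1`: 100000 nM
- compound 3 `CCCCCCCCCCCC[C@@H](O)[C@H]1CC[C@H]([C@H](O)CCCCCCCCCCNC(=O)c2ccsc2)O1`: 2190 nM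

In this assay, compound 3 stands with compound 1 at the low end of these numbers: a 1.1-fold higher number from compound 1 to compound 3 (0.04 log units; within the scatter). It lies far from compound 2: a 46-fold lower number from compound 2 to compound 3 (1.66 log units; beyond the scatter).

The next analogue is compound 4 `CCCCCCCCCCCC[C@@H](O)[C@H]1CC[C@H]([C@H](O)CCCCCCCCCCNC(=O)c2ccnn2C)O1`, which keeps the shared core and changes only the ring on the amide carbonyl: 1-methyl-1H-pyrazol-5-yl in place of thiophen-3-yl on a carbonyl carbon. Among the measured compounds shown here, no measured compound carries 1-methyl-1H-pyrazol-5-yl, so the measured steps offer only indirect guidance. Moving between the two thiophene attachments gave a 1.1-fold higher number from compound 1 to compound 3 (0.04 log units; within the scatter), whereas replacing thiophen-2-yl with furan-2-yl gave a 50-fold higher number from compound 1 to compound 2 (1.70 log units; beyond the scatter). Ring exchange at this place can therefore be silent or large. Since the entering ring, like furan-2-yl, is not a thiophene, a clear step towards higher numbers in this assay is expected, probably smaller than the furan step.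

For compound 4 the estimated value is 15000 nM, with an expected range of 3000 nM to 80000 nM. This estimate means an expected 6.8-fold higher number from compound 3 to compound 4 (0.84 log units; beyond the scatter).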

Compound 4, concentration for 50% growth inhibition: 100000 nM
The estimate for compound 4 lay 6.7-fold (0.82 log units) below the measured number; the measured number lies above the stated range.
By their numbers in this assay, from the lowest: compounds 1 and 3 (each within the scatter of the next); then compounds 2 and 4 (each within the scatter of the next).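

In this assay, a second non-thiophene ring on this carbonyl carbon falls on the weak side, 1-methyl-1H-pyrazol-5-yl in place of thiophen-3-yl giving a large step (a 46-fold higher number from compound 3 to compound 4 (1.66 log units; beyond the scatter)) and the same exchange from thiophen-2-yl another (a 50-fold higher number from compound 1 to compound 4 (1.70 log units; beyond the scatter)). Exchanging furan-2-yl for the same ring gives no change at the digits printed from compound 2 to compound 4 (within the scatter), so the sharp rise is no longer unique to furan-2-yl, and among these four compounds only the two thiophene attachments keep the low numbers. Nothing available here accounts for this split between the rings.

The compounds shown leave open whether a phenyl or pyridin-3-yl ring at this place would stay with the thiophenes or join the other two rings. They also leave open whether a pyrazole ring without its methyl group would behave as compound 4 does.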